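A few compounds are considered here, and "the series" means these few. Any claim that something is new, unique, unknown or untested is made for them only; others in the source may bear on it.

Measured so far:
compound 1 `Cc1oc(-c2c(Cl)cccc2Cl)nc1CN1CCC(C(=O)NCCCN2C[C@H](C)C[C@H](C)C2)CC1`: 13200 nM
compound 2 `Cc1ccccc1-c1nc(CN2CCC(C(=O)NCCCN3CCCC(CC(C)C)C3)CC2)c(C)o1`: 4640 nM
compound 3 `Cc1ccccc1-c1nc(CN2CCC(C(=O)N3CCN(C4CCN(C)CC4)CC3)CC2)c(C)o1`: 19900 nM

Three compounds sharing the same core were tested in an ADME assay on Huh7.5.1 cells (Homo sapiens) for cytotoxicity, read by ATP content, with a stated time of 48 h; a higher number here means that more compound is tolerated, a lower number that less compound is tolerated. Compound 1 gives 13200 nM, the second highest of the three numbers. Its nearest neighbour is compound 3, which gives 19900 nM, a gap that lies within the scatter of repeated measurements, so the two cannot be ranked against each other. The furthest is compound 2, which gives 4640 nM, a gap beyond the scatter; compound 2 is thus tolerated less than compound 1.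

Compound 4 `Cc1cc(C)cc(-c2nc(CN3CCC(C(=O)NCCCN4C[C@H](C)C[C@H](C)C4)CC3)c(C)o2)c1` has not yet been measured in this assay. It differs from compound 1 in one place: 3,5-dimethylphenyl in place of 2,6-dichlorophenyl on an aromatic carbon. The group that leaves and the group that enters match in size, in ring type and in count of donors and acceptors.

For the measured compounds named here, no step between two measured compounds that differ only in this place is available, so the size of the change rests on the values of compounds 1, 2 and 3 alone, which span a modest range in this assay. Compound 4 is therefore expected to lie close to compound 1, with an expected step of a 1.1-fold lower number from compound 1 to compound 4 (0.04 log units; within the scatter) that stays within the scatter. The estimate for compound 4 is 12000 nM, with a range from 5000 nM to 30000 nM.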

Compound 4, half-maximal cytotoxic concentration: 4050 nM
For compound 4 the middle estimate is 3.0-fold (0.47 log units) above the measured one; measured number outside the range, below it.
By their numbers in this assay, from the lowest: compounds 4 and 2 (each within the scatter of the next); then compounds 1 and 3 (each within the scatter of the next).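

Swapping 2,6-dichlorophenyl for 3,5-dimethylphenyl on the aromatic carbon next to the ring nitrogen and next to the ring oxygen gives a 3.3-fold lower number from compound 1 to compound 4 (0.51 log units; beyond the scatter) in this assay, the first step read at this position, and it shows that the position is not indifferent to the group it carries. The group that leaves and the group that enters match in heavy-atom count, ring type and count of donors and acceptors, so matching these counts does not keep the number in place, and less of compound 4 is tolerated than of compound 1. No measurement at hand bears on why the number falls.

The compounds shown leave open whether the step goes with the chlorine atoms or with their placement on the phenyl ring, as the two change together here, and a 2,6-dimethylphenyl or 3,5-dichlorophenyl group at this position would separate them. Also open, going by these compounds, is how far an amine or a carboxylic acid on that phenyl ring would move the number, and in which direction.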